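A few compounds are considered here, and "the series" means these few. Any claim that something is new, unique, unknown or untested is made for them only; others in the source may bear on it.

Of the compounds shown here, three sharing one core have been measured in a functional assay (B cells) with Mus musculus as the target; on this read-out lower numbers stand for an effect already at smaller amounts and higher numbers for an effect only at larger amounts of compound. Compound 1 `Nc1nc(O)c2c(n1)n(C1OC(CO)[C@@H](O)[C@H]1O)c(=O)n2Cc1ccc(Cl)cc1` gives 14 uM, compound 2 `Nc1nc(O)c2c(n1)n(C1OC(CO)[C@@H](O)[C@H]1O)c(=O)n2Cc1ccc([N+](=O)[O-])cc1` gives 40 uM, and compound 3 `CCOC(=O)Cn1c(=O)n(C2OC(CO)[C@@H](O)[C@H]2O)c2nc(N)nc(O)c21` gives 48 uM, the highest of the three numbers. Compound 4 `[N-]=[N+]=NCC(O)Cn1c(=O)n(C2OC(CO)[C@@H](O)[C@H]2O)c2nc(N)nc(O)c21` is not yet measured; it differs from compound 3 by 2-azido-1-hydroxyethyl in place of ethoxycarbonyl on a saturated chain carbon bound to an aromatic nitrogen. The measured steps that bear on this change sit at the same place on the chain: a 3.4-fold higher number from compound 1 to compound 3 (0.54 log units; beyond the scatter) and a 1.2-fold higher number from compound 2 to compound 3 (0.08 log units; within the scatter). Swapping the group on that chain carbon has so far shifted the number modestly or not beyond the scatter, and nothing measured contains the entering 2-azido-1-hydroxyethyl group. Compound 4 is therefore expected to stay near compound 3, with an expected step of a 1.3-fold higher number from compound 3 to compound 4 (0.10 log units; within the scatter). The estimate for compound 4 in this assay is 60 uM, from 25 uM to 150 uM.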

Compound 4, concentration for half-maximal effect: 39 uM
Estimate against measurement, compound 4: 1.5-fold (0.19 log units) above; measured number inside the range.
By their numbers in this assay, from the lowest: compound 1; then compounds 4, 2 and 3 (each within the scatter of the next).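

In this assay putting 2-azido-1-hydroxyethyl on a saturated chain carbon bound to an aromatic nitrogen gives a 1.2-fold lower number from compound 3 to compound 4 (0.09 log units; within the scatter) in place of ethoxycarbonyl and a 1.0-fold lower number from compound 2 to compound 4 (0.01 log units; within the scatter) in place of 4-nitrophenyl. Both steps lie within the scatter, so this ring-free group with a hydrogen-bond donor cannot be told apart from either one. In place of 4-chlorophenyl it gives a 2.8-fold higher number from compound 1 to compound 4 (0.44 log units; beyond the scatter) which leaves compound 1 alone beyond the scatter of the other three. Nothing measured here explains these results.

As far as these compounds go, whether a simple amine, a carboxylic acid or a longer chain at this place would separate from compound 4 stays open. So does whether a 4-bromophenyl group would match 4-chlorophenyl.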